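The source may report more compounds than this note shows. Statements on the series, on what has been measured and on what is new or still open speak of the compounds shown alone.

Working notes on the series, measured in a functional assay on the whole organism for inhibition, with Rattus norvegicus as the target, at a dose of 1 mg/kg by the oral route; on this read-out lower numbers stand for a weaker effect and higher numbers for a stronger effect at the one dose given. Two compounds have numbers. Compound 1, `COc1ccc(-c2cc(Cl)cc(C(=O)Nc3nn[nH]n3)n2)cc1OC`, gives 15% in this assay. Compound 2, `COc1ccc(-c2cc(OC)cc(C(=O)Nc3nn[nH]n3)n2)cc1`, gives 25% in this assay. Compound 2 stands at the larger of the two numbers shown, but the gap to compound 1 is within the scatter, so the two are not separated by this read-out; no difference between their structures is worked out here, and only their two values are of note.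

Compound 3, `COc1cc(C(=O)Nc2nn[nH]n2)nc(-c2ccc(OC)c(OC)c2)c1`, is not yet measured. It differs from compound 2 by methoxy in place of hydrogen on an aromatic carbon. The new methoxy sits on an aromatic carbon of a six-membered aromatic ring of carbon only, ortho to a methoxy group and meta to a large group.

Going by the values given here, no step between two measured compounds is available, so the size of this change in this assay has no precedent. Given that the two measured compounds sit within the scatter of each other, the step is expected to be none beyond the scatter, in either direction. For compound 3 the estimate is 25%, with a range from 8% to 45%, meaning an expected step of no change at the digits printed from compound 2 to compound 3 (within the scatter).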

Compound 3, a percentage reported as inhibition, in the whole organism at one dose (the size of the read-out at that dose, not a potency): 18%
Estimate against measurement, compound 3: 7 percentage points above, and the stated range covers the measured number.
By their numbers in this assay, from the lowest: compounds 1, 3 and 2 (each within the scatter of the next).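

In this assay, methoxy in place of hydrogen on an aromatic carbon of the six-membered aromatic ring of carbon only, ortho to a methoxy group and meta to a large group, gives the first step read at this position: a number 7 percentage points lower from compound 2 to compound 3 (within the scatter) and so no separation at the one dose given. The second step, methoxy in place of chloro on an aromatic carbon of the shared core, reads a number 3 percentage points higher from compound 1 to compound 3 (within the scatter) and is likewise no separation, so neither change is shown to alter the size of the read-out in this series. The compounds offer no measurement that bears on the reason for these numbers.

Open, going by these compounds, is whether any group on the carbon that carries the new methoxy can move the read-out beyond the scatter, for instance an amine, a carboxylic acid or a longer chain such as butoxy in place of that methoxy. Also open, on these data alone, is whether an amine or a longer chain in place of the methoxy or chloro on the aromatic carbon of the shared core would separate from compound 3 in this assay at this dose.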